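This account rests on a few compounds, and the source may have more. Where it says the series, first, only, none or still open, it means among the compounds named here.

Measured so far: compound 1 `CC(C)(C)c1cc(NC(=O)Nc2ccc(-c3cn4ccccc4n3)cc2)no1` gives 3.09 nM in a functional assay on MV4-11 cells (Homo sapiens) for cytotoxicity, read by MTT assay, with a stated time of 72 h; a higher number here means a weaker inhibitor, a lower number a stronger inhibitor; compound 2 `CC(C)(C)c1cc(NC(=O)Nc2ccc(-c3cn4cc(Br)ccc4n3)cc2)no1` gives 44.5 nM in the same assay.

For the measured compounds named here, compound 2 stands at the higher of the two numbers, and its only neighbour is compound 1, which lies a long way under it: the change of bromo in place of hydrogen on an aromatic carbon gave a 14-fold higher number from compound 1 to compound 2 (1.16 log units; beyond the scatter), a step well beyond the scatter.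

Compound 3 `Cc1ccc2nc(-c3ccc(NC(=O)Nc4cc(C(C)(C)C)on4)cc3)cn2c1` has not yet been measured in this assay. It differs from compound 2 in one place: methyl in place of bromo on an aromatic carbon. Going by the values given here, no measured pair shows methyl against bromo, or methyl against hydrogen, at this carbon. Among the compounds with values here, the one step that bears on the position is the one from compound 1 to compound 2, which shows that placing a group there raised the number strongly. Since compound 3 keeps a group at that carbon, though a different one, the expected number for compound 3 is 15 nM (range 4 nM to 60 nM), that is an expected step of a 3.0-fold lower number from compound 2 to compound 3 (0.47 log units; beyond the scatter), downward from compound 2 but probably still above compound 1.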

Compound 3, half-maximal inhibitory concentration: 4.08 nM
Compound 3: the middle estimate sits 3.7-fold (0.57 log units) above what was measured; low and high end bracket the measured number.
By their numbers in this assay, from the lowest: compounds 1 and 3 (each within the scatter of the next); then compound 2.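

In this assay, for the compounds shown here, the carbon that carries bromo in compound 2 does not penalise every group, as the one earlier step of a 14-fold higher number from compound 1 to compound 2 (1.16 log units; beyond the scatter) might have suggested. Methyl in place of bromo gave an 11-fold lower number from compound 2 to compound 3 (1.04 log units; beyond the scatter) and so undid nearly all of that rise, a large step beyond the scatter. Methyl in place of hydrogen gave a 1.3-fold higher number from compound 1 to compound 3 (0.12 log units; within the scatter) and stays within the scatter, so among these three compounds the carbon tolerates methyl as well as hydrogen, and the loss is tied to bromo alone.

Nothing available explains why bromo and methyl part so widely at this carbon.

With only hydrogen, methyl and bromo shown at this position, it remains open how a chloro, a methoxy, an amine, a carboxylic acid or a longer chain such as ethyl would fall relative to these three compounds. The rest of the shared core is also the same in all of them, so they do not tell whether the gap between bromo and methyl would persist if another part of the molecule changed.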